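The source may hold more compounds than are shown below. What is called first, only, known or untested is meant among the compounds shown, and "the series" means these compounds.

Measured so far in a functional assay for inhibition, tested at 100 ug/mL; a higher number here means a stronger effect of the compound at the concentration tested, a lower number a weaker effect:
compound 1 `COc1cc(-c2cc(-c3cc(C(C)C)c(O)cc3C)[nH]c(=O)c2C#N)cc(OC)c1OC` gives 84.5%
compound 2 `COc1ccc(-c2cc(-c3cc(C(C)C)c(O)cc3C)[nH]c(=O)c2C#N)cc1` gives 54%
compound 3 `COc1cc(-c2cc(-c3cc(C(C)C)c(O)cc3C)[nH]c(=O)c2C#N)ccc1O` gives 44%

Compound 2 holds the second highest of the three numbers. Its nearest neighbour is compound 3, whose value lies a little lower but within the usual scatter of repeated measurements, so the two cannot be told apart with confidence. The furthest is compound 1, whose value lies well above that of compound 2, beyond the scatter.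

The step to compound 4 `Cc1cc(O)c(C(C)C)cc1-c1cc(-c2ccccc2Cl)c(C#N)c(=O)[nH]1` alters one group on the shared core: 2-chlorophenyl in place of 4-methoxyphenyl on an aromatic carbon. Going by the values given here, only one measured step touches the same place, the one from compound 2 to compound 3, which put 4-hydroxy-3-methoxyphenyl in place of 4-methoxyphenyl: a number 10 percentage points lower from compound 2 to compound 3 (within the scatter). That swap left the read-out essentially unchanged. Among the compounds with values here, a 2-chlorophenyl has no precedent among the measured compounds, and compound 1 with 84.5% shows that a different ring at this place can raise the number considerably, so the range must stay wide. The step expected in this assay is small, a number 9 percentage points lower from compound 2 to compound 4 (within the scatter). Compound 4 is estimated at 45%, between 20% and 75%.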

Compound 4, a percentage reported as inhibition, at one concentration (the size of the read-out at that concentration, not a potency): 34%
Compound 4: the middle estimate sits 11 percentage points above what was measured; measured number inside the range.
By their numbers in this assay, from the lowest: compounds 4, 3 and 2 (each within the scatter of the next, the first and the last beyond it); then compound 1.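

In this assay, the swap to 2-chlorophenyl gives a number 20 percentage points lower from compound 2 to compound 4 (beyond the scatter), so a change on this aromatic carbon, ortho to the cyano group, can lower the read-out by more than the scatter, which the earlier step from compound 2 did not show. Against the other ring the picture is less clear, with a number 10 percentage points lower from compound 3 to compound 4 (within the scatter), so compound 3 and compound 4 cannot be told apart with confidence. The swap removes the methoxy group and brings in a chlorine at a different place on the phenyl ring, these two changes cannot be separated with the compounds shown, and no independent measurement bears on what lies behind the result.

Still open, from the compounds shown here alone, is whether the chlorine itself or its place on the ring matters, which 4-chlorophenyl and 2-methoxyphenyl at this carbon would help to separate, with plain phenyl as a reference. Also open, going by these compounds, is how a ring carrying an amine or a carboxylic acid would compare with compound 1 , which stands at 84.5%.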